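The source may report more compounds than this note shows. Statements on the series, on what has been measured and on what is new or still open speak of the compounds shown alone.

Compound 3 `C=CC1=C(C(=O)NC2CCCCC2)C(c2ccc(OC)cc2)OC1` gives in a functional assay on SW480 cells (Homo sapiens) for cytotoxicity, read by MTT assay, with a stated time of 24 h (a lower number here means a stronger inhibitor, a higher number a weaker inhibitor), a value of > 100000 nM, which is a limit of the measurement and not a number. It therefore sits at the weak end of the three measured compounds, sharing (the limit of > 100000 nM in this assay, at which 2 of the 3 values shown sit). Going by the values given here, compound 1 `C=CC1=C(C(=O)NCc2ccccc2)C(c2ccc(OC)cc2)OC1` gives in this assay 39500 nM, the only numerical value among the three. Compound 2 `C=CC1=C(C(=O)Nc2ccc(OCC)cc2)C(c2ccc(OC)cc2)OC1` gives > 100000 nM, again a limit. The step of an at least 2.5-fold higher number from compound 1 to compound 3 (0.40 log units; beyond the scatter) is known only as a lower bound, as is the step of an at least 2.5-fold higher number from compound 1 to compound 2 (0.40 log units; beyond the scatter); the step that the two limits leave unreadable from compound 2 to compound 3 runs between two limits and cannot be read at all.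

Compound 4 `C=CC1=C(C(=O)NCCC)C(c2ccc(OC)cc2)OC1` differs from compound 3 by propyl in place of cyclohexyl on an amide-type nitrogen. Among the compounds with values here, no measured step pairs the amide-nitrogen group of compound 4 with any other, so no step bears on this change directly; the only related steps lead from compound 1 up to limits. Compound 4 is therefore expected to stay weak, with the step of a number no higher from compound 3 to compound 4 (the limit leaves the size open) estimated as unreadable, and its estimated value is 100000 nM, between 30000 nM and 300000 nM.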

Compound 4, half-maximal inhibitory concentration: > 100000 nM
Compound 4 was reported as a limit; the forecaster's own chance of this, stated with the estimate: 60%; the middle value lies on the limit itself.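

In this assay compound 4 gives > 100000 nM, which is a limit of the measurement. Going by these compounds alone, putting ethyl in place of the phenyl of the benzyl group gives an at least 2.5-fold higher number from compound 1 to compound 4 (0.40 log units; beyond the scatter), so a small open chain on the amide-type nitrogen does not match benzyl, and compound 1 remains the only compound with a numerical value. Propyl, cyclohexyl and 4-ethoxyphenyl on this nitrogen now all share one reading: the limit of > 100000 nM in this assay, at which 3 of the 4 values shown sit.

The steps among compound 2, compound 3 and compound 4 run between limits and cannot be read, so any differences among these three groups stay hidden. Also open, from the compounds shown here alone, is whether a phenethyl group, with its longer chain to the phenyl ring, or a benzyl group carrying an amine or a carboxylic acid, would give a stronger or weaker value than benzyl.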